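Working notes: the amine substituent from compound 1 to compound 3

This account rests on a few compounds, and the source may have more. Where it says the series, first, only, none or still open, it means among the compounds named here.

Compound 1 `NC(=O)c1c(NC(=O)Nc2ccc(Cl)cc2)sc2c1CCN(CC1CCC1)C2` carries a cyclobutylmethyl group on its amine nitrogen in a ring, and in a functional assay (strain AB) with Danio rerio as the target, read by microscopy, with a stated time of 1 h (on this read-out lower numbers stand for an effect already at smaller amounts and higher numbers for an effect only at larger amounts of compound), compound 1 gives 1360 nM, the lowest of the two numbers in hand. Compound 2 `CCN1CCc2c(sc(NC(=O)Nc3cccc(C)c3)c2C(N)=O)C1` gives 13000 nM in this assay, a gap beyond the scatter; the two compounds differ in several places, so no single change can be read from that pair. Compound 3 `CC(C)(C)OC(=O)CCCCN1CCc2c(sc(NC(=O)Nc3ccc(Cl)cc3)c2C(N)=O)C1` carries the change (3-(tert-butoxycarbonyl)propyl in place of cyclobutyl on a saturated chain carbon bound to an amine nitrogen in a ring). Going by the values given here, no measured step of this kind exists, so the expectation for compound 3 in this assay is a modest loss, a 1.8-fold higher number from compound 1 to compound 3 (0.26 log units; within the scatter), roughly at the edge of the scatter. Compound 3 is estimated at 2500 nM, within 800 nM to 8000 nM.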

Compound 3, half-maximal effective concentration: 710 nM
Compound 3: the middle estimate sits 3.5-fold (0.55 log units) above what was measured; measured number below the stated range.
By their numbers in this assay, from the lowest: compounds 3 and 1 (each within the scatter of the next); then compound 2.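

At this position, on a saturated chain carbon bound to an amine nitrogen in a ring, 3-(tert-butoxycarbonyl)propyl in place of cyclobutyl gives a 1.9-fold lower number from compound 1 to compound 3 (0.28 log units; within the scatter) in this assay and so leaves the read-out within the scatter. The position therefore accepts loss of the four-membered ring and a group with more heavy atoms, including oxygen, without a separable shift in this read-out. No measured evidence bears on why the two compounds read alike.

Still open, as far as these compounds go, is whether a free carboxylic acid or an amine at the end of the chain would read the same. From the compounds shown here alone, a shorter chain at this position is equally open.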